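The compounds below may be only part of what the source reports. "The series", "measured", "known", "first", "only" and "open" are said of these compounds alone.

Measured compounds:
compound 1, `COc1ccc(-c2ccc3c(NCCCNCc4cccc(OC)c4O)ccnc3c2)cc1`: 1600 nM
compound 2, `c1ccc(CCc2ccc3c(NCCCNCc4ccco4)ccnc3c2)cc1`: 16000 nM
compound 3, `COc1ccc(-c2ccc3c(NCCCNCc4ccco4)ccnc3c2)cc1`: 6000 nM

In an ADME assay on HepG2 cells (Homo sapiens) for cytotoxicity, read by luminescence, CellTiter-Glo and ATP content, with a stated time of 72 h (a lower number here means that less compound is needed, a higher number that more compound is needed for the effect), compound 1 gives 1600 nM, the lowest of the three numbers. The nearest is compound 3, with 6000 nM; the step is a 3.8-fold higher number from compound 1 to compound 3 (0.57 log units; beyond the scatter). Within the data shown here, compound 2, with 16000 nM, stands furthest from compound 1, and no single-point step links those two.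

Compound 4, `COc1cccc(CNCCCNc2ccnc3cc(Oc4ccc(F)cc4)ccc23)c1O`, is the next entry. It differs from compound 1 in one place: 4-fluorophenoxy in place of 4-methoxyphenyl on an aromatic carbon

Among the measured compounds shown here, of the measured steps, only one bears on a change at this position of the shared core: a 2.7-fold lower number from compound 2 to compound 3 (0.43 log units; beyond the scatter), a modest shift beyond the scatter. The other step, a 3.8-fold higher number from compound 1 to compound 3 (0.57 log units; beyond the scatter), concerns the chain substituent and says nothing direct about the core position. There is thus one modest precedent for exchanging the group on that aromatic carbon; its size is that of a 2.7-fold lower number from compound 2 to compound 3 (0.43 log units; beyond the scatter). For compound 4 a step of similar modest size is expected, direction uncertain, leaning toward a somewhat higher number than compound 1: a 1.6-fold higher number from compound 1 to compound 4 (0.19 log units; within the scatter). The estimate for compound 4 in this assay is 2500 nM, with a range from 800 nM to 8000 nM.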

Compound 4, half-maximal effective concentration: 11000 nM
Compound 4: the middle estimate sits 4.4-fold (0.64 log units) below what was measured; the measured number lies above the stated range.
By their numbers in this assay, from the lowest: compound 1; then compounds 3, 4 and 2 (each within the scatter of the next, the first and the last beyond it).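

In this assay, the aromatic carbon of the shared core proves sensitive even to an exchange that leaves the heavy-atom, donor and acceptor counts and the single six-membered aromatic ring unchanged: 4-fluorophenoxy in place of 4-methoxyphenyl gives a 6.9-fold higher number from compound 1 to compound 4 (0.84 log units; beyond the scatter). Together with a 2.7-fold lower number from compound 2 to compound 3 (0.43 log units; beyond the scatter), this makes two pairs at this carbon, each with a different chain group, and in both the compound with 4-methoxyphenyl has the lower number, whether the other group is phenethyl or 4-fluorophenoxy; no compound shown goes against this, though two pairs make only a narrow pattern. No measurement shown here offers an explanation for the size of the new step.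

The compounds shown do not separate the oxygen that links the ring to the core from the exchange of methoxy for fluorine, and a 4-fluorophenyl or a 4-methoxyphenoxy group on this carbon would separate the two. Also open, as far as these compounds go, is whether the step from 4-methoxyphenyl to 4-fluorophenoxy keeps its size with furan-2-yl on the chain, and how a non-aromatic group such as morpholine would read at this carbon.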